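Methoxy for phenyl on the benzyl arm

The source may report more compounds than this note shows. Statements on the series, on what has been measured and on what is new or still open speak of the compounds shown alone.

Measured compounds:
compound 1 `O=S(=O)(NCCCNCC1COc2ccccc2O1)c1cc(C(F)(F)F)cc(C(F)(F)F)c1` — 2700 nM
compound 2 `O=S(=O)(NCCCNCc1ccc(-c2ccccc2)cc1)c1cc(C(F)(F)F)cc(C(F)(F)F)c1` — 2700 nM

In a functional assay on HPAC cells (Homo sapiens) for inhibition, read by MTT assay, with a stated time of 72 h (a higher number here means a weaker inhibitor of growth, a lower number a stronger inhibitor of growth), compound 1 gives 2700 nM. Level with compound 1 in this assay, compound 2 gives 2700 nM, a difference that lies within the scatter. Compound 3 `COc1ccc(CNCCCNS(=O)(=O)c2cc(C(F)(F)F)cc(C(F)(F)F)c2)cc1` differs from compound 2 by methoxy in place of phenyl on an aromatic carbon. Within the data shown here, no measured step covers this change. A small shift toward weaker growth inhibition is expected, a 1.3-fold higher number from compound 2 to compound 3 (0.11 log units; within the scatter), at most just beyond the scatter. Compound 3 is therefore estimated at 3500 nM, with a range from 1500 nM to 9000 nM.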

Compound 3, concentration for 50% growth inhibition: 3000 nM
Estimate against measurement, compound 3: 1.2-fold (0.07 log units) above, and the stated range covers the measured number.
By their numbers in this assay, from the lowest: compounds 1, 2 and 3 (each within the scatter of the next).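

In this assay, methoxy in place of phenyl on an aromatic carbon, para to a large group, gives a 1.1-fold higher number from compound 2 to compound 3 (0.05 log units; within the scatter), so this position accepts the loss of the aromatic ring without a shift beyond the scatter. The step of 4-methoxyphenyl in place of 2,3-dihydro-1,4-benzodioxin-2-yl on a saturated chain carbon bound to an amine nitrogen, a 1.1-fold higher number from compound 1 to compound 3 (0.05 log units; within the scatter), also stays within the scatter. Nothing available explains why these numbers stay level. As far as these compounds go, whether an amine or a carboxylic acid at this aromatic carbon would move the number beyond the scatter remains open. So does the effect of a longer chain in the shared core.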